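A few compounds are considered here, and "the series" means these few. Any claim that something is new, unique, unknown or untested is made for them only; others in the source may bear on it.

Measured compounds:
compound 1 `COc1ccc(-c2cc(/C=C/C(=O)c3ccc(N)cc3)[nH]n2)cc1` — 76%
compound 2 `COc1cc(-c2cc(/C=C/C(=O)c3ccc(N)cc3)[nH]n2)cc(OC)c1OC` — 81%
compound 3 `COc1ccc(C(=O)/C=C/c2cc(-c3cc(OC)c(OC)c(OC)c3)n[nH]2)cc1OC` — 69%

In a functional assay on OVCAR-8 cells (Homo sapiens) for cytotoxicity, read by sulforhodamine B assay, with a stated time of 48 h, tested at 1 uM (a higher number here means a weaker effect of the compound at the concentration tested, a lower number a stronger effect), compound 2 gives 81%, the highest of the three numbers. Compound 1 gives 76%, which lies within the scatter of compound 2. Compound 3 gives 69%; the step of a number 12 percentage points lower from compound 2 to compound 3 (beyond the scatter) is the only one beyond the scatter, and it comes from changing the aryl group on the carbonyl carbon, not the aryl group on the shared core.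

Compound 4 `COc1ccc(-c2cc(/C=C/C(=O)c3ccc(N)cc3)[nH]n2)cc1OC` differs from compound 2 by hydrogen in place of methoxy on an aromatic carbon. Within the data shown here, no measured step touches this position directly. The closest comparison is compound 1 against compound 2, where the aryl group on the shared core carries one methoxy group instead of three, and the two values fall within the scatter of each other. Compound 4 sits between these two structures, so no step beyond the scatter is expected in this assay.

Compound 4 is therefore estimated at 78%, with a range from 66% to 90%. The expected step of a number 3 percentage points lower from compound 2 to compound 4 (within the scatter) is small.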

Compound 4, a percentage reported as activity, at one concentration (the size of the read-out at that concentration, not a potency): 93%
Estimate against measurement, compound 4: 15 percentage points below, and the stated range ends below it.
By their numbers in this assay, from the lowest: compounds 3, 1 and 2 (each within the scatter of the next, the first and the last beyond it); then compound 4.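

In this assay, hydrogen in place of methoxy on an aromatic carbon gives a number 12 percentage points higher from compound 2 to compound 4 (beyond the scatter), while methoxy in place of hydrogen on an aromatic carbon gives a number 17 percentage points higher from compound 1 to compound 4 (beyond the scatter). Opposite changes on the same aromatic ring thus arrive at compound 4, and both raise the number, so the read-out does not move in one direction as methoxy groups are added to this ring across these pairs. Nothing available here accounts for this reversal.

From the compounds shown here alone, whether a hydroxyl group, an amine or a fluorine atom at this position would give a number closer to that of compound 2 or of compound 4 remains open. Also open, going by these compounds, is whether the same change keeps its direction with 3,4-dimethoxyphenyl on the carbonyl carbon, as in compound 3.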